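An open chain replaces the ring at compound 2

The compounds below may be only part of what the source reports. "The series", "measured", "known", "first", "only" and "open" are said of these compounds alone.

Compound 1 (`N[C@H]1CC[C@H](Oc2ccc([C@H]3CC[C@]4(CC3)OOC3(O4)C4CC5CC(C4)CC3C5)cc2)CC1`) and compound 2 (`NC1CCN(S(=O)(=O)c2ccc([C@H]3CC[C@]4(CC3)OOC3(O4)C4CC5CC(C4)CC3C5)cc2)CC1`) share one core, and both were read in an ADME assay on microsomes from liver (Homo sapiens) for metabolic stability, read by LC-MS, tested at 1 uM (on this read-out lower numbers stand for slow clearance and higher numbers for fast clearance), without yielding a number. Compound 1 gives < 7 mL.min-1.g-1 which is only a limit. Compound 2 gives < 7 mL.min-1.g-1 which is again a limit and not a number. Compound 2 therefore stands on the limit of < 7 mL.min-1.g-1 in this assay, at which 2 of the 2 values shown sit, and has no number of its own. Among the compounds with values here, the only measured step is a step that the two limits leave unreadable from compound 1 to compound 2 and it brings (4-aminopiperidin-1-yl)sulfonyl in place of (4-aminocyclohexyl)oxy on an aromatic carbon. Compound 3 (`NCCS(=O)(=O)CCOc1ccc([C@H]2CC[C@]3(CC2)OOC2(O3)C3CC4CC(C3)CC2C4)cc1`) departs from compound 2 in one place (2-((2-aminoethyl)sulfonyl)ethoxy in place of (4-aminopiperidin-1-yl)sulfonyl on an aromatic carbon) with 2-((2-aminoethyl)sulfonyl)ethoxy in place of (4-aminopiperidin-1-yl)sulfonyl on an aromatic carbon, para to a large group. Within the data shown here, the only guide is a step that the two limits leave unreadable from compound 1 to compound 2 so no step beyond the scatter is expected in this assay and no direction can be given. The expected change is a step that the limit leaves unreadable from compound 2 to compound 3 and a reading that is again only a limit is likely. Compound 3 is estimated at 6 mL.min-1.g-1 with an expected range from 3 mL.min-1.g-1 to 14 mL.min-1.g-1 as its upper end.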

Compound 3, intrinsic clearance in microsomes: 9 mL.min-1.g-1
Compound 3: the middle estimate sits 1.5-fold (0.18 log units) below what was measured, and the stated range covers the measured number.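

In this assay compound 3 is the first compound shown to give a number and not a limit, so the open chain 2-((2-aminoethyl)sulfonyl)ethoxy, which has no ring, gives this position on an aromatic carbon, para to a large group, its first measured reading. Exchanging (4-aminopiperidin-1-yl)sulfonyl for this chain gives an at least 1.2-fold higher number from compound 2 to compound 3 (0.10 log units; that floor lies within the scatter), and setting 2-((2-aminoethyl)sulfonyl)ethyl in place of 4-aminocyclohexyl on the oxygen gives an at least 1.2-fold higher number from compound 1 to compound 3 (0.10 log units; that floor lies within the scatter), so neither step is shown to exceed the scatter. Both steps can be read only as floors because the two compounds they start from carry no number of their own: the limit of < 7 mL.min-1.g-1 in this assay, at which 2 of the 3 values shown sit.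

On these data alone, the true size of either step therefore remains open, and with it the question of whether the ring and the open chain differ at all in this read-out. As far as these compounds go, it also remains open how the reading would respond to a carboxylic acid in place of the amine of the chain, or to a longer chain on the same oxygen.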